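The compounds below may be only part of what the source reports. "The series", "measured", "known", "first", "only" and "open" are said of these compounds alone.

In a functional assay on the whole organism for inhibition, with Mythimna separata as the target, with a stated time of 5 days (a lower number here means that less compound is needed, a higher number that more compound is needed for the effect), compound 1 `CC(C)(C)n1ncc(OCc2nnc(-c3cccs3)o2)c(Cl)c1=O` reaches only > 300 ug/mL, which is a limit of the assay rather than a number. Compound 2 `CC(C)(C)n1ncc(OCc2nnc(-c3ccc(F)cc3)o2)c(Cl)c1=O` gives 5.2 ug/mL. Compound 3 `CC(C)(C)n1ncc(OCc2nnc(-c3ccc(Cl)cc3F)o2)c(Cl)c1=O` gives 10.4 ug/mL.

Within the data shown here, compound 3 thus sits beside compound 2, since a 2.0-fold higher number from compound 2 to compound 3 (0.30 log units; within the scatter) lies within the scatter, and the only other value shown is the limit of compound 1 (the limit of > 300 ug/mL in this assay, at which 1 of the 3 values shown sits). Compound 4 `Cc1cccc(-c2nnc(COc3cnn(C(C)(C)C)c(=O)c3Cl)o2)c1` differs from compound 3 by 3-methylphenyl in place of 4-chloro-2-fluorophenyl on an aromatic carbon. The steps of an at least 57-fold lower number from compound 1 to compound 2 (1.76 log units; beyond the scatter) and an at least 28-fold lower number from compound 1 to compound 3 (1.46 log units; beyond the scatter) show a large gain when a six-membered carbon ring replaces thiophen-2-yl, whereas a 2.0-fold higher number from compound 2 to compound 3 (0.30 log units; within the scatter) shows the substituents on that ring changing little. Compound 4 keeps such a ring, so the step of a 1.2-fold higher number from compound 3 to compound 4 (0.06 log units; within the scatter) is expected to stay near the scatter. Compound 4 is therefore estimated at 12 ug/mL, between 3 ug/mL and 60 ug/mL.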

Compound 4, half-maximal effective concentration: 116 ug/mL
Beside the measured number, compound 4's estimate is 9.7-fold (0.99 log units) below it, outside the stated range (above it).
By their numbers in this assay, from the lowest: compounds 2 and 3 (each within the scatter of the next); then compound 4. At a limit, above all of these: compound 1.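

A six-membered carbon ring on this aromatic carbon does not by itself keep the number low: in this assay, the change to 3-methylphenyl gives an 11-fold higher number from compound 3 to compound 4 (1.05 log units; beyond the scatter) and a 22-fold higher number from compound 2 to compound 4 (1.35 log units; beyond the scatter), so the ring's substituents can matter here after all. Compared with thiophen-2-yl, 3-methylphenyl still shows an at least 2.5-fold lower number from compound 1 to compound 4 (0.41 log units; beyond the scatter). That step rests on a limit for compound 1: the limit of > 300 ug/mL in this assay, at which 1 of the 4 values shown sits.

As far as these compounds go, whether the change follows from the methyl group itself or from its place on the ring stays open. From the compounds shown here alone, how a methoxy group or a nitrile on that ring would read also stays open.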